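Moving the amine around the ring in a cytotoxic scaffold

The source may report more compounds than this note shows. Statements on the series, on what has been measured and on what is new or still open speak of the compounds shown alone.

Four compounds share one core, a five-membered ring bearing two carbonyls, linked through a double bond to a phenyl group and carrying a benzyl-type group on its nitrogen. Compound 1 `Nc1ccc(/C=C2\SC(=O)N(Cc3ccc(C(F)(F)F)cc3)C2=O)cc1` has a trifluoromethyl on the benzyl and a 4-aminophenyl group; in a functional assay on CCRF-CEM cells (Homo sapiens) for cytotoxicity, read by cell counting, with a stated time of 3 days (a lower number here means a stronger inhibitor, a higher number a weaker inhibitor), compound 1 gives 32000 nM. Compound 2 `C=C(Br)C(=O)Nc1ccc(/C=C2\SC(=O)N(Cc3ccccc3)C2=O)cc1` carries an acylated amine, and in this assay compound 2 gives 2300 nM. Going by these compounds, compound 3 `Nc1cccc(/C=C2\SC(=O)N(Cc3ccccc3)C2=O)c1` has the amine on the 3-aminophenyl group; in this assay compound 3 reaches only a limit, > 250000 nM, and so its true value is unknown (the limit of > 250000 nM in this assay, at which 1 of the 3 values shown sits). Compound 4 `Nc1ccc(/C=C2\SC(=O)N(Cc3ccccc3)C2=O)cc1` is the not yet measured partner: 4-aminophenyl in place of 3-aminophenyl on a double-bonded chain carbon bound to a double-bonded ring carbon. Compound 1 shows that a 4-aminophenyl group with a benzyl-type nitrogen substituent gives a measurable number, so compound 4 is expected to sit well within the measurable range. The expected step from compound 3 to compound 4 is therefore towards stronger inhibition, an at least 6.2-fold lower number from compound 3 to compound 4 (0.79 log units; beyond the scatter). Compound 4 is estimated at 40000 nM, within 10000 nM to 200000 nM.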

Compound 4, half-maximal inhibitory concentration: 42000 nM
Compound 4: middle estimate off by 1.1-fold (0.02 log units), on the low side; the range from low to high includes it.
By their numbers in this assay, from the lowest: compound 2; then compounds 1 and 4 (each within the scatter of the next). At a limit, above all of these: compound 3.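

In this assay, moving the amine alone, with the benzyl group unchanged, has a clear effect: 4-aminophenyl in place of 3-aminophenyl gives an at least 5.9-fold lower number from compound 3 to compound 4 (0.77 log units; beyond the scatter), a size that is only a bound, as one end of it is a limit of the assay: the limit of > 250000 nM in this assay, at which 1 of the 4 values shown sits.

The trifluoromethyl on the benzyl group, by contrast, makes no readable difference, since hydrogen in its place gives a 1.3-fold higher number from compound 1 to compound 4 (0.12 log units; within the scatter). Acylation of the amine does count: hydrogen in place of the (1-bromoethenyl)carbonyl group gives an 18-fold higher number from compound 2 to compound 4 (1.26 log units; beyond the scatter).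

Still open, going by these compounds, is whether that acyl effect needs the bromoethenyl part, which a plain acetyl on the same nitrogen would test. Also open, on these data alone, is whether the nitrogen itself matters at the 4-position, which a hydroxyl in place of the amine would test.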